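This account rests on a few compounds, and the source may have more. Where it says the series, first, only, none or still open, it means among the compounds named here.

Measured compounds:
Compound 2 `Cn1ccc2c(Oc3ccc(NC(=O)c4cc5cccnc5n(-c5ccc(Br)cc5F)c4=O)cc3)ccnc21` gives 1630 nM in a functional assay on A549 cells (Homo sapiens) for antiproliferative activity, read by MTT assay, with a stated time of 72 h; on this read-out lower numbers stand for stronger inhibition and higher numbers for weaker inhibition.
Compound 1 `O=C(Nc1ccc(Oc2ccnc3[nH]ccc23)cc1)c1cc2cccnc2n(-c2ccc(C(F)(F)F)cc2Cl)c1=O` gives 3230 nM in this assay.

Of the compounds shown here, two have been measured. Compound 2 gives 1630 nM and compound 1 gives 3230 nM; the two numbers sit within the scatter of each other, so neither can be told apart from the other on this read-out. For the measured compounds named here, the two structures differ in more than one place, and no single step between them has been worked out, so only their two values can be compared.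

Compound 3 `Cn1ccc2c(Oc3ccc(NC(=O)c4cc5cccnc5n(-c5ccc(C(F)(F)F)cc5Cl)c4=O)cc3)ccnc21` has not yet been measured. It differs from compound 2 in one place: 2-chloro-4-(trifluoromethyl)phenyl in place of 4-bromo-2-fluorophenyl on an aromatic nitrogen. Going by the values given here, the group that enters is the one carried by compound 1, while the remainder of compound 3 is that of compound 2. Since compound 1 with this same aryl group gives 3230 nM, a number close to that of compound 2, a step of the size a 1.5-fold higher number from compound 2 to compound 3 (0.17 log units; within the scatter) is expected, one that does not go beyond the scatter. For compound 3 a value of 2400 nM is therefore estimated, with a range from 900 nM to 6500 nM.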

Compound 3, half-maximal inhibitory concentration: 8250 nM
For compound 3 the middle estimate is 3.4-fold (0.54 log units) below the measured one; the measured number lies above the stated range.
By their numbers in this assay, from the lowest: compounds 2 and 1 (each within the scatter of the next); then compound 3.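

In this assay, the aryl group on the aromatic nitrogen of the six-membered ring proves able to shift the number: with the rest of the structure held fixed, 2-chloro-4-(trifluoromethyl)phenyl in place of 4-bromo-2-fluorophenyl gives a 5.1-fold higher number from compound 2 to compound 3 (0.70 log units; beyond the scatter), a modest change that lies beyond the scatter. The second single-place comparison, methyl in place of hydrogen on an aromatic nitrogen with the 2-chloro-4-(trifluoromethyl)phenyl group kept, gives a 2.6-fold higher number from compound 1 to compound 3 (0.41 log units; beyond the scatter), also modest and beyond the scatter, so both changes raise the number in these single comparisons, which the earlier pair, differing in more than one place, could not show. No accompanying measurement bears on either step.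

The aryl swap replaces both substituents at once, so these compounds cannot say whether the step follows the halogen or the trifluoromethyl group, or what an unsubstituted phenyl or a methoxy group would give there. Going by these compounds, it also remains open whether the methyl step would have the same size with 4-bromo-2-fluorophenyl in place, or how an ethyl group on that nitrogen would compare.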